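Swapping the Amine Arm of Compound 1

This account rests on a few compounds, and the source may have more. Where it says the series, first, only, none or still open, it means among the compounds named here.

Three compounds sharing one core were tested in an assay on cells for inhibition of Amine oxidase [flavin-containing] B (Homo sapiens), read by fluorescence, with a stated time of 30 min, tested at 10 uM; on this read-out higher numbers stand for more inhibition at the one concentration tested (going by the name of the read-out) and lower numbers for less inhibition. Compound 1 `COc1cc2c(cc1OC)C(=O)/C(=C/c1ccc(CN(C)Cc3ccccc3)c(O)c1)O2` gives 17.8%, the lowest of the three numbers. Compound 2 `CCN(CC)Cc1cc(/C=C2\Oc3cc(OC)c(OC)cc3C2=O)cc(CN(CC)CC)c1O` gives 32.7%, and compound 3 `COc1cc2c(cc1OC)C(=O)/C(=C/c1ccc(O)cc1)O2` gives 36.1%; both of these gaps to compound 1 lie beyond the scatter. The unmeasured compound 4 `COc1cc2c(cc1OC)C(=O)/C(=C/c1ccc(CN3CCCCC3)c(O)c1)O2` differs from compound 1 in one place: piperidin-1-yl in place of benzyl(methyl)amino on a saturated chain carbon bound to an aromatic carbon. Within the data shown here, no measured pair shows this exact change, so its size can only be guessed. In this assay the expected step is a number 4.2 percentage points higher from compound 1 to compound 4 (within the scatter), which is small, perhaps slightly upward, and within the usual scatter. Compound 4 is therefore expected to give about 22%, with a range from 8% to 38%.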

Compound 4, a percentage reported as inhibition, at one concentration (the size of the read-out at that concentration, not a potency): 32%
Estimate against measurement, compound 4: 10 percentage points below, within the range that was stated.
By their numbers in this assay, from the lowest: compound 1; then compounds 4, 2 and 3 (each within the scatter of the next).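

In this assay putting piperidin-1-yl in place of benzyl(methyl)amino gives a number 14.2 percentage points higher from compound 1 to compound 4 (beyond the scatter) and so shows that the choice of amine on this saturated chain carbon can change the read-out. Among these compounds, the change swaps an aromatic ring of carbon only for a non-aromatic ring holding the nitrogen, and it is the only direct comparison at this position. Nothing on hand explains the rise. On these data alone, how a pyrrolidine ring, a morpholine ring or a simple dimethylamino group would read at the same place remains open.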